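Shifting an Acetamide Methyl in Fluoro-Methoxybenzyl Amides

The source may report more compounds than this note shows. Statements on the series, on what has been measured and on what is new or still open speak of the compounds shown alone.

Three benzyl amides have been measured in an assay on isolated protein for agonist activity at melatonin receptor type 1C (Xenopus laevis), read by spectrophotometry; on this read-out lower numbers stand for smaller maximal responses and higher numbers for larger maximal responses. Compound 1 `COc1ccc(CNC(C)=O)cc1F` gives 77%. Compound 2 `CCC(=O)NCc1ccc(OC)c(F)c1` gives 51%. Compound 3 `COc1cc(CNC(C)=O)ccc1F` gives 83%, which lies within the usual scatter of the value of compound 1, so no order between compound 1 and compound 3 is claimed.

Compound 2 is derived from compound 1 by one change, (methyl in place of hydrogen on a saturated chain carbon bound to a carbonyl carbon), and this produced a number 26 percentage points lower from compound 1 to compound 2 (beyond the scatter).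

Compound 3 shares all its atoms with compound 1 but joins them differently; how the two cores differ is not broken down here.

Compound 4 `CCC(=O)NCc1ccc(F)c(OC)c1` is not yet measured. It differs from compound 3 by methyl in place of hydrogen on a saturated chain carbon bound to a carbonyl carbon, the same change, at the same place, that led from compound 1 to compound 2.

If the step is carried over, the expectation for compound 4 is a number 26 percentage points lower from compound 3 to compound 4 (beyond the scatter) in this assay, resting on the one measured instance of this change, a number 26 percentage points lower from compound 1 to compound 2 (beyond the scatter). On that basis compound 4 is estimated at 57%, with a likely range from 42% to 72%.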

Compound 4, largest response reached (reported as efficacy), in percent of the reference or control that the assay uses: 86%
Compound 4: middle estimate off by 29 percentage points, on the low side; the whole stated range lies below it.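

In this assay, the methyl that turns the acetamido group of compound 3 into a propanoylamino group gave a number 3 percentage points higher from compound 3 to compound 4 (within the scatter), so the drop seen on the core of compound 1 did not recur on this second core. The two steps differ, and the change did not carry over from one core to the other in this series: the same change on two cores in this assay, a number 26 percentage points lower (beyond the scatter) from compound 1 to compound 2 and a number 3 percentage points higher (within the scatter) from compound 3 to compound 4, 29 percentage points apart, beyond the scatter of two such steps. For the compounds shown here, this shows that the outcome of this single change varied with the core, but with only one pair on each core it does not show which difference between the cores is responsible, nor what the change would do on a further core.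

Going by these compounds, it remains open whether a longer chain than propanoyl, or an amine or a carboxylic acid at the end of that chain, would follow the trend of compound 1 and compound 2 or that of compound 3 and compound 4. On these data alone, whether the two cores would part in the same way on any other read-out also remains open.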